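The source may hold more compounds than are shown below. What is called first, only, known or untested is meant among the compounds shown, and "the series" means these compounds.

Measured in a functional assay on the whole organism with Mus musculus as the target, in the maximal electroshock model; a higher number here means that more compound is needed for the effect, a lower number that less compound is needed:
- Compound 1 `OC1CCN(c2ccc(-c3ccc(F)cc3)nn2)CC1`: 48 mg/kg
- Compound 2 `CNC(=O)OC1CCN(c2ccc(-c3ccc(Cl)cc3Cl)nn2)CC1`: 5.5 mg/kg

Of these two compounds, compound 2 has the lower number, so less of it is needed for the effect. The gap to compound 1 lies beyond the usual scatter of repeated measurements.

Compound 3 (`CNC(=O)OC1CCN(c2ccc(-c3ccc(F)cc3)nn2)CC1`) has not yet been measured. It comes from compound 2 through a single change, 4-fluorophenyl in place of 2,4-dichlorophenyl on an aromatic carbon.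

Going by the values given here, no measured pair shows this change by itself, so any forecast remains loose. Among the compounds with values here, the only guide is that compound 1 also carries 4-fluorophenyl, and compound 1 gives 48 mg/kg. A moderate move toward a higher number in this assay is therefore expected, though one that may not clearly exceed the scatter. The expected change is a 2.5-fold higher number from compound 2 to compound 3 (0.41 log units; beyond the scatter). For compound 3 the estimated value is 14 mg/kg, with an expected range from 5 mg/kg to 40 mg/kg.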

Compound 3, dose for half-maximal effect: 40 mg/kg
Estimate against measurement, compound 3: 2.9-fold (0.46 log units) below; low and high end bracket the measured number.
By their numbers in this assay, from the lowest: compound 2; then compounds 3 and 1 (each within the scatter of the next).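

In this assay, putting 4-fluorophenyl in place of 2,4-dichlorophenyl on the aromatic carbon gives a 7.3-fold higher number from compound 2 to compound 3 (0.86 log units; beyond the scatter) while the methylcarbamoyl group stays the same, so the group at this position clearly affects how much compound is needed. With 4-fluorophenyl in place, putting methylcarbamoyl in place of hydrogen on the oxygen gives a 1.2-fold lower number from compound 1 to compound 3 (0.08 log units; within the scatter) and stays within the scatter, so this pair shows no readable effect of that group. No measurement at hand explains why the change at the aromatic carbon has such a large effect.

The step from compound 2 to compound 3 removes both chlorine atoms and adds a fluorine atom in one move, so it cannot tell which of these differences matters; a 4-chlorophenyl or a plain phenyl group at the same position would help separate them. As far as these compounds go, it also remains open whether methylcarbamoyl matters with 2,4-dichlorophenyl, which a partner of compound 2 carrying a free hydroxyl in its place could show.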